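The source may hold more compounds than are shown below. What is called first, only, known or untested is meant among the compounds shown, and "the series" means these compounds.

Measured compounds in an assay on isolated protein for inhibition of Cholecystokinin receptor type A (Rattus norvegicus); a higher number here means a weaker inhibitor, a lower number a stronger inhibitor:
Compound 1, `CCCCCN(CCCCC)C(=O)C(CCC(=O)OCc1ccccc1)NC(=O)Nc1ccc(Cl)cc1`: 9300 nM
Compound 2, `CCCCCN(CCCCC)C(=O)C(CCC(=O)N1CCCC1)NC(=O)Nc1ccc(Cl)cc1`: 680 nM
Compound 3, `CCCCCN(CCCCC)C(=O)[C@@H](CCC(=O)O)NC(=O)Nc1cccc(OC)c1`: 540 nM

Compound 3 gives the lowest number of the three in this assay. Its nearest neighbour is compound 2, and the gap between them lies within the scatter, so no order can be read between them; its furthest neighbour is compound 1, and that gap lies beyond the scatter. For the measured compounds named here, the one measured step, a 14-fold lower number from compound 1 to compound 2 (1.14 log units; beyond the scatter), concerns an exchange at the carbonyl end of the side chain, not the configuration of the chain carbon.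

Compound 4, `CCCCCN(CCCCC)C(=O)[C@H](CCC(=O)O)NC(=O)Nc1cccc(OC)c1`, is the next point. The change from compound 3: the two compounds have the same atoms and bonds and differ only in configuration as drawn: 1 of 1 stereo elements differ; a stereocentre at a saturated chain carbon is drawn R in compound 3 and S in compound 4. Going by the values given here, no measured step in this assay touches configuration, and compounds 1 and 2 are drawn without a defined configuration at that carbon, so they give no guide on the size or direction of such a step. Among the compounds with values here, the expectation therefore rests on the single value of compound 3 alone, and the range is set wide to reflect that. Compound 4 is expected to give 2000 nM in this assay, with a range from 300 nM to 15000 nM. The step this estimate implies, a 3.7-fold higher number from compound 3 to compound 4 (0.57 log units; beyond the scatter), is expected to run toward a higher number, with a result inside the scatter not excluded.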

Compound 4, half-maximal inhibitory concentration: 4.5 nM
Compound 4: the middle estimate sits 440-fold (2.65 log units) above what was measured; measured number below the stated range.
By their numbers in this assay, from the lowest: compound 4; then compounds 3 and 2 (each within the scatter of the next); then compound 1.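

In this assay, for the compounds shown here, the configuration at the saturated chain carbon emerges as a major variable, with a 120-fold lower number from compound 3 to compound 4 (2.08 log units; beyond the scatter) and the lower number belonging to the form drawn S. The only earlier step, a 14-fold lower number from compound 1 to compound 2 (1.14 log units; beyond the scatter), concerned the carbonyl end of the side chain and said nothing about this stereocentre, while compounds 1 and 2 are drawn without a defined configuration there. The whole of the new step can be assigned to this one stereocentre, because no other structural change accompanies it: the fact that compounds 3 and 4 differ only in the configuration as drawn

Still open, going by these compounds, is whether the preference for the form drawn S carries over to the compounds with the chlorophenyl urea or the pyrrolidin-1-yl amide, since the values of compounds 1 and 2 cannot be assigned to either configuration. Also open, on these data alone, is how far the low number of compound 4, 4.5 nM, depends on the carboxylic acid at the end of the side chain, which a tetrazole or a primary amide in the same configuration would test.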